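Swapping one small aromatic ring for another on the amide nitrogen

The source may report more compounds than this note shows. Statements on the series, on what has been measured and on what is new or still open speak of the compounds shown alone.

Measured compounds:
compound 1, `CC(C)[C@H](C(=O)Nc1cccnn1)c1ccc(Cl)cc1`: 101%
compound 2, `CC(C)[C@H](C(=O)Nc1ccon1)c1ccc(Cl)cc1`: 90%

These two compounds share a core and differ only in the ring attached to the amide-type nitrogen. In a functional assay on CHO cells for agonist activity at Free fatty acid receptor 2 (Homo sapiens), read by cAMP accumulation (a higher number here means a larger maximal response, a lower number a smaller maximal response), compound 1 gives 101%, and compound 2 gives 90%. Going by the values given here, the single measured step is a number 11 percentage points lower from compound 1 to compound 2 (beyond the scatter). Among the compounds with values here, compound 2 therefore stands at the lower of the two numbers seen so far, with compound 1 the only neighbour, and that neighbour above it by more than the usual scatter.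

Compound 3, `CC(C)[C@H](C(=O)Nc1cnns1)c1ccc(Cl)cc1`, has not yet been measured. It differs from compound 2 in one place: 1,2,3-thiadiazol-5-yl in place of 1,2-oxazol-3-yl on an amide-type nitrogen

Within the data shown here, the only step that bears on this change is the one from compound 1 to compound 2, a modest drop when one five-membered ring took the place of a six-membered one. Here a five-membered ring replaces another five-membered ring, so the step of a number 2 percentage points higher from compound 2 to compound 3 (within the scatter) is expected to stay within the scatter. Compound 3 is expected to give about 92% in this assay, somewhere between 75% and 108%.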

Compound 3, largest response reached (reported as efficacy), in percent of the reference or control that the assay uses: 48%
Compound 3: the middle estimate sits 44 percentage points above what was measured; the whole stated range lies above it.
By their numbers in this assay, from the lowest: compound 3; then compound 2; then compound 1.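

Putting 1,2,3-thiadiazol-5-yl in place of 1,2-oxazol-3-yl on the amide-type nitrogen gives in this assay a large change, a number 42 percentage points lower from compound 2 to compound 3 (beyond the scatter) and putting it in place of pyridazin-3-yl gives another, a number 53 percentage points lower from compound 1 to compound 3 (beyond the scatter). This shows that ring size alone does not set the maximal response here: the two five-membered aromatic rings have the same number of heavy atoms and no hydrogen-bond donors, yet they differ by far more than the earlier step between the six-membered and the five-membered ring, a number 11 percentage points lower from compound 1 to compound 2 (beyond the scatter). Among these three compounds, then, the response depends on which hetero atoms the ring carries and how many, and not only on the size of the ring.

No measurement available here explains why the response falls with this ring. On these data alone, it stays open whether the sulfur or the added ring nitrogen matters more, a question that a comparison with a 1,3-thiazol-2-yl ring or a 1,3,4-oxadiazol-2-yl ring on the same nitrogen could help to answer.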